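Ethyl to tert-butyl in a growth inhibition series

A few compounds are considered here, and "the series" means these few. Any claim that something is new, unique, unknown or untested is made for them only; others in the source may bear on it.

In a functional assay on SMMC-7721 cells (Homo sapiens) for inhibition, read by CCK-8 assay, with a stated time of 72 h, tested at 2 uM (a lower number here means less inhibition of growth, a higher number more inhibition of growth at the concentration tested), compound 1 (`CCc1ccc(SCc2ccc(/C=C/C(=O)Nc3ccccc3N)cc2)cc1`) gives 13.2% as its reading. Compound 2 (`COc1ccc(SCc2ccc(C(=O)Nc3ccccc3N)cc2)cc1OC`) gives 20.2% as its reading, within the scatter of compound 1. Compound 3 (`Nc1ccccc1NC(=O)c1ccc(CSCCc2ccccc2)cc1`) gives 28.1% as its reading, higher than compound 1 and beyond the scatter. Compound 1 therefore shares the low end of these numbers with compound 2.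

The next compound is compound 4 (`CC(C)(C)c1ccc(SCc2ccc(/C=C/C(=O)Nc3ccccc3N)cc2)cc1`), with tert-butyl in place of ethyl on an aromatic carbon, para to a large group (tert-butyl in place of ethyl on an aromatic carbon). Among the compounds with values here, no measured pair isolates this change, since compound 2 and compound 3 each differ from compound 1 in more than one place. The expectation therefore starts from compound 1 at 13.2% as its reading. In this assay no step beyond the scatter is expected, with a slight rise at most. The estimated step (a number 2.8 percentage points higher from compound 1 to compound 4 (within the scatter)) is small and expected to be upward. For compound 4 the estimated value is 16% (expected range 5% to 30%).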

Compound 4, percent growth inhibition at one concentration: 18.3%
For compound 4 the middle estimate is 2.3 percentage points below the measured one; measured number inside the range.
By their numbers in this assay, from the lowest: compounds 1, 4, 2 and 3 (each within the scatter of the next, the first and the last beyond it).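

Read in this assay, 4-ethylphenyl to 4-(tert-butyl)phenyl gives a number 5.1 percentage points higher from compound 1 to compound 4 (within the scatter) and is the first step in the series that isolates a single place. On this aromatic carbon, para to a large group, the larger tert-butyl can replace ethyl with no difference that this read-out can separate from the usual scatter, so this position accepts both groups at the concentration tested. No measurement at hand bears on why the two groups read alike.

Open, on these data alone, is whether an amine, a carboxylic acid or a longer chain in place of ethyl at this position would give a step beyond the scatter. Also open is whether ethyl and tert-butyl would still read alike at other concentrations, as only one concentration is shown.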